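Swapping 4-methylphenyl for 3,4-difluorophenyl in compound 1

The compounds below may be only part of what the source reports. "The series", "measured", "known", "first", "only" and "open" are said of these compounds alone.

In an ADME assay on MT4 cells (Homo sapiens) for cytotoxicity, read by MTT assay (a lower number here means that less compound is tolerated, a higher number that more compound is tolerated), compound 1 `Cc1ccc(C(=O)N(C(=S)OCCN2C(=O)c3ccccc3C2=O)c2ccc(Cl)cc2)cc1` gives > 100000 nM as its reading, which is a limit and not a number. Compound 1 stands at the limit of > 100000 nM in this assay, at which 1 of the 3 values shown sits, in this small set. Compound 2 `Cc1ccc(N(C(=O)c2ccccc2[N+](=O)[O-])C(=S)OCCN2C(=O)c3ccccc3C2=O)cc1` gives 100000 nM and compound 3 `Cc1ccc(C(=O)N(C(=S)OCCN2C(=O)c3ccccc3C2=O)c2ccc(C)cc2)cc1` gives 83000 nM in the same test. Compound 4 `O=C1c2ccccc2C(=O)N1CCOC(=S)N(C(=O)c1ccc(F)c(F)c1)c1ccc(Cl)cc1` differs from compound 1 by one change, (3,4-difluorophenyl in place of 4-methylphenyl on a carbonyl carbon), with 3,4-difluorophenyl in place of 4-methylphenyl on a carbonyl carbon. The measured change at that carbonyl carbon is a 1.2-fold lower number from compound 2 to compound 3 (0.08 log units; within the scatter) and methyl in place of chloro on an aromatic carbon gives an at least 1.2-fold lower number from compound 1 to compound 3 (0.08 log units; that floor lies within the scatter), both within the scatter. No step beyond the scatter is therefore expected in this assay for this change. The estimated step is an at least 1.1-fold lower number from compound 1 to compound 4 (0.04 log units; that floor lies within the scatter), which stays small. Compound 4 is expected at 90000 nM, with an estimated range of 45000 nM to 100000 nM overall.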

Compound 4, half-maximal cytotoxic concentration: 52000 nM
Compound 4: the middle estimate sits 1.7-fold (0.24 log units) above what was measured; low and high end bracket the measured number.
By their numbers in this assay, from the lowest: compounds 4, 3 and 2 (each within the scatter of the next).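

Within the data shown here, at this carbonyl carbon, 3,4-difluorophenyl in place of 4-methylphenyl gives an at least 1.9-fold lower number from compound 1 to compound 4 (0.28 log units; that floor lies within the scatter), the first reading for a fluorine-carrying group at this place. Even so, this change cannot be said to lower the number in this assay. The reading of compound 1 is a limit and not a number, so the true size of the step stays open: the limit of > 100000 nM in this assay, at which 1 of the 4 values shown sits.

The compounds shown carry only aromatic groups at this carbonyl carbon. Going by these compounds, what an amine or a carboxylic acid on that ring, or a saturated cyclohexyl group in its place, would do remains open.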